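This account rests on a few compounds, and the source may have more. Where it says the series, first, only, none or still open, it means among the compounds named here.

Working notes on the series. Of the compounds shown here, two have numbers so far. Compound 1 `CCc1cc(OC)c(S(C)(=O)=O)cc1C(=O)N=C(N)N` gives 30 nM in a functional assay for inhibition of sodium/hydrogen exchanger (Oryctolagus cuniculus); a higher number here means a weaker inhibitor, a lower number a stronger inhibitor. Compound 2 `CS(=O)(=O)c1cc(C(=O)N=C(N)N)ccc1C#N` gives 140 nM in this assay, the highest of the two numbers; its nearest neighbour is compound 1, whose number is lower by a margin beyond the usual scatter. Among the compounds with values here, no pair differing in one place has been measured, so no single step is settled.

Compound 3 `COc1ccc(C(=O)N=C(N)N)cc1S(C)(=O)=O` is the next to be measured. It differs from compound 2 by methoxy in place of cyano on an aromatic carbon. Compound 1 also carries a methoxy group and gives 30 nM, but it differs from compound 3 in a further place as well, so the methoxy-for-cyano swap cannot be read off directly.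

Expectation: a modest drop in the number from compound 2 to compound 3, a 2.0-fold lower number from compound 2 to compound 3 (0.30 log units; within the scatter), of about the size of the scatter or a little beyond it. Compound 3 is estimated at 70 nM, with a range from 25 nM to 200 nM.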

Compound 3, half-maximal inhibitory concentration: 270 nM
Estimate against measurement, compound 3: 3.9-fold (0.59 log units) below; the measured number lies above the stated range.
By their numbers in this assay, from the lowest: compound 1; then compounds 2 and 3 (each within the scatter of the next).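

In this assay, methoxy in place of cyano on the aromatic carbon ortho to a methylsulfonyl group gives a 1.9-fold higher number from compound 2 to compound 3 (0.29 log units; within the scatter), so the two groups are not told apart at this position. The larger step lies at another place: hydrogen in place of ethyl on an aromatic carbon gives a 9.0-fold higher number from compound 1 to compound 3 (0.95 log units; beyond the scatter), which ties the low number of compound 1 to its ethyl group rather than to its methoxy group. Nothing available bears on the reason for either step.

Still open, as far as these compounds go, is whether a longer chain or a chlorine atom in place of ethyl would keep a number as low as that of compound 1. Also open, from the compounds shown here alone, is whether an amine in place of methoxy would read like methoxy and cyano, and whether the ethyl step would carry over to a compound bearing cyano.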